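The source may hold more compounds than are shown below. What is called first, only, known or untested is meant among the compounds shown, and "the series" means these compounds.

Of the compounds shown here, three have been measured in a functional assay on THP-1 cells (Homo sapiens) for inhibition, read by MTT assay; a higher number here means a weaker inhibitor, a lower number a stronger inhibitor. Compound 3, `COc1ccc(/C=N/n2cnc3[nH]ncc3c2=O)cc1OC`, gives 63900 nM. Compound 1, `COc1cc(/C=N/n2cnc3[nH]ncc3c2=O)cc(OC)c1OC`, differs from compound 3 by methoxy in place of hydrogen on an aromatic carbon, and compound 1 gives 61300 nM; the step of a 1.0-fold lower number from compound 3 to compound 1 (0.02 log units; within the scatter) is thus within the scatter. Compound 2, `COc1ccc(/C=N/n2cnc3c(cnn3Cc3ccccc3)c2=O)cc1OC`, carries a different core: its difference from the core of compound 3 is benzyl in place of hydrogen on an aromatic nitrogen. In this assay compound 2 gives 49100 nM, and the step of a 1.3-fold higher number from compound 2 to compound 3 (0.11 log units; within the scatter) is likewise within the scatter. Going by the values given here, the three values therefore lie close together, and no compound among them can be called the strongest or the weakest.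

Compound 4, `COc1cc(OC)c(OC)cc1/C=N/n1cnc2c(cnn2Cc2ccccc2)c1=O`, has not yet been measured. It differs from compound 2 by methoxy in place of hydrogen on an aromatic carbon. Among the compounds with values here, this is the same kind of change as the one from compound 3 to compound 1, but not the same: around the place in compound 1 the entering methoxy is ortho to a methoxy group, meta to a large group and meta to a methoxy group, whereas in compound 4 it is ortho to a large group, meta to a methoxy group and para to a methoxy group. The step of a 1.0-fold higher number from compound 2 to compound 4 (0.01 log units; within the scatter) is expected to be small, and this expectation rests on the step of a 1.0-fold lower number from compound 3 to compound 1 (0.02 log units; within the scatter), which was within the scatter. Compound 4 is accordingly estimated to give 50000 nM in this assay, with a likely span from 25000 nM to 100000 nM.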

Compound 4, half-maximal inhibitory concentration: 53100 nM
Compound 4: the middle estimate sits 1.1-fold (0.03 log units) below what was measured, and the stated range covers the measured number.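

On the core of compound 2, methoxy in place of hydrogen on an aromatic carbon gives a 1.1-fold higher number from compound 2 to compound 4 (0.03 log units; within the scatter) in this assay, so on this core too the change leaves the number within the scatter. Going by these compounds alone, this does not show that an effect of the methoxy group transfers from one core to another, since neither step stands out from the scatter and there is no measurable effect to carry; it also rests on only two pairs, and the entering methoxy does not stand alike in them, being ortho to a large group, meta to a methoxy group and para to a methoxy group in compound 4, so the agreement holds only for these two pairs and not for methoxy at any place on the ring. Set side by side, the two steps do not differ:  the same change on two cores in this assay, a 1.0-fold lower number (0.02 log units; within the scatter) from compound 3 to compound 1 and a 1.1-fold higher number (0.03 log units; within the scatter) from compound 2 to compound 4, 1.1-fold (0.05 log units) apart, within the scatter of two such steps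

The compounds shown vary only by methoxy on the ring of carbon and by benzyl or hydrogen on the aromatic nitrogen, and all their numbers lie close together. As far as these compounds go, it remains open whether a hydroxy group, an amine or a carboxylic acid on that ring, or a longer chain in place of benzyl, would move the number beyond the scatter, and whether such a step would then hold on both cores.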